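The source may hold more compounds than are shown below. What is called first, only, known or untested is meant among the compounds shown, and "the series" means these compounds.

The study compares three measured purine-type compounds and one still to be tested, all carrying a chloromethyl-substituted benzyl group on the shared core. Compound 1 `ClCc1ccc(Cn2cnc3c(Cl)ncnc32)cc1` bears the chloromethyl group in one arrangement on the benzyl ring, while compound 2 `ClCc1cccc(Cn2cnc3ncnc(Cl)c32)c1` has the same atoms joined differently; the difference between the two cores is not broken down here. Compound 3 `ClCc1ccc(Cn2cnc3c(Cl)nc(Cl)nc32)cc1` carries an extra chloro in place of hydrogen on an aromatic carbon relative to compound 1 (chloro in place of hydrogen on an aromatic carbon).

In a functional assay on CAKI-1 cells (Homo sapiens) for cytotoxicity, read by sulforhodamine B assay, with a stated time of 48 h (on this read-out higher numbers stand for weaker inhibition of growth and lower numbers for stronger inhibition of growth), compound 1 gives 640 nM. Compound 2 gives 4070 nM in this assay, and compound 3 gives 21400 nM. Going by the values given here, the one counted step is a 33-fold higher number from compound 1 to compound 3 (1.52 log units; beyond the scatter), so adding the chloro weakened growth inhibition markedly. Compound 2 stands between the other two, and its values alone show it sits closer to compound 3 than to compound 1.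

Compound 4 `ClCc1cccc(Cn2cnc3nc(Cl)nc(Cl)c32)c1` has not yet been measured. It differs from compound 2 by chloro in place of hydrogen on an aromatic carbon, the same change that separates compound 1 from compound 3, at a place described in identical words. Among the compounds with values here, the expected step from compound 2 to compound 4 is a 17-fold higher number from compound 2 to compound 4 (1.24 log units; beyond the scatter), which rests on the single observed step of a 33-fold higher number from compound 1 to compound 3 (1.52 log units; beyond the scatter), tempered because only one example exists. Compound 4 is therefore estimated to give 70000 nM in this assay, with a range expected from 15000 nM to 300000 nM.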

Compound 4, concentration for total growth inhibition: 3460 nM
Compound 4: middle estimate off by 20-fold (1.31 log units), on the high side; measured number below the stated range.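

In this assay, going by these compounds alone, chloro in place of hydrogen on the aromatic carbon between two ring nitrogen atoms gives a 1.2-fold lower number from compound 2 to compound 4 (0.07 log units; within the scatter), so on the core of compound 2 this change produces no step that can be told apart from the scatter. Set beside the earlier step on the core of compound 1, the result shows that the large step seen there did not carry over to the second core, and that the size of this change depends on the core that bears it, at least for these two pairs: the same change on two cores in this assay, a 33-fold higher number (1.52 log units; beyond the scatter) from compound 1 to compound 3 and a 1.2-fold lower number (0.07 log units; within the scatter) from compound 2 to compound 4, 39-fold (1.59 log units) apart, beyond the scatter of two such steps With only two pairs, however, it does not show which feature of the two cores sets the steps apart, nor does it give a rule for what the same change would do on any further core in the series.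

All four compounds shown carry a chloromethyl group on the benzyl ring and at least one chloro on the shared core, so they leave open whether the gap between the two steps would persist with a different group on the benzyl ring, such as a hydroxymethyl or a methyl group. They also leave open how an amine or a methoxy group at the carbon that takes the new chloro would compare with hydrogen or chloro on either core.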